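Methoxy for Amino: What to Expect for Compound 4

The source may report more compounds than this note shows. Statements on the series, on what has been measured and on what is new or still open speak of the compounds shown alone.

Of the compounds shown here, three have so far been tested in an ADME assay on HEK293 cells (Homo sapiens) for inhibition, read by MTT assay, with a stated time of 2 days; on this read-out higher numbers stand for weaker inhibition and lower numbers for stronger inhibition. Compound 1 `Nc1ccccc1/C=C/c1ccccc1O` gives 27 ug/mL. Compound 2 `Nc1ccccc1/C=C/c1cccc(O)c1` is built from the same atoms as compound 1 but joined differently, and how its core differs from that of compound 1 is not broken down here; in this assay compound 2 gives 20 ug/mL. Compound 3 `COc1ccccc1/C=C/c1ccccc1O` gives 15 ug/mL in this assay. These three values all lie within the scatter of one another, so no order among them can be read.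

Compound 3 arises from compound 1 by a single change, (methoxy in place of amino on an aromatic carbon), and that change produced a 1.8-fold lower number from compound 1 to compound 3 (0.26 log units; within the scatter). The unmeasured compound 4 `COc1ccccc1/C=C/c1cccc(O)c1` arises from compound 2 by the same change, (methoxy in place of amino on an aromatic carbon), at a place described in the same words, so it is the same change appearing a second time. The expectation for compound 4 rests on this one measured step, because the change gave a 1.8-fold lower number from compound 1 to compound 3 (0.26 log units; within the scatter) and is seen nowhere else. The step from compound 2 to compound 4 is therefore expected to be a 1.7-fold lower number from compound 2 to compound 4 (0.22 log units; within the scatter). Compound 4 is expected to give about 12 ug/mL in this assay, most likely between 6 ug/mL and 25 ug/mL.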

Compound 4, half-maximal inhibitory concentration: 24 ug/mL
Compound 4: the middle estimate sits 2.0-fold (0.30 log units) below what was measured; the range from low to high includes it.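

On the core of compound 2, methoxy in place of amino gives a 1.2-fold higher number from compound 2 to compound 4 (0.08 log units; within the scatter) in this assay. Set beside the first case, the change shows no measurable difference between the two cores: the same change on two cores in this assay, a 1.8-fold lower number (0.26 log units; within the scatter) from compound 1 to compound 3 and a 1.2-fold higher number (0.08 log units; within the scatter) from compound 2 to compound 4, 2.2-fold (0.33 log units) apart, within the scatter of two such steps. This does not prove that the change acts alike on both cores, and it does not show that the change has any effect on either one, as both steps are small enough to be scatter alone, and two such steps cannot separate a small shared effect from the noise of repeated measurements.

The compounds shown carry only amino or methoxy at this place, so it remains open what an ethoxy group, a longer chain or a carboxylic acid would give there. From the compounds shown here alone, it also remains open whether a step clear of the scatter can be found at this place on either core.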